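A few compounds are considered here, and "the series" means these few. Any claim that something is new, unique, unknown or untested is made for them only; others in the source may bear on it.

Measured so far in an assay on HEK293 cells for inhibition of Voltage-dependent T-type calcium channel subunit alpha-1G (Homo sapiens), read by patch clamp, tested at 10 uM; on this read-out higher numbers stand for more inhibition at the one concentration tested (going by the name of the read-out) and lower numbers for less inhibition:
- compound 1 `COc1ccccc1N1CCN(C[C@@H](O)COc2ccc(F)cc2)CC1`: 50.7%
- compound 2 `COc1ccccc1N1CCN(C[C@@H](O)COc2ccc(Cl)cc2)CC1`: 47.4%
- compound 3 `O[C@H](COc1ccc(Cl)cc1)CN1CCN(c2ccc(F)cc2)CC1`: 28.3%

Compound 1 and compound 2 share one core; compound 3 has another, and the difference between the two cores is not broken down here. Within the first core the change fluoro in place of chloro on an aromatic carbon gives a number 3.3 percentage points higher from compound 2 to compound 1 (within the scatter). Compound 3 stands lowest of the three in this assay, and its gaps to compound 2 and to compound 1 are both beyond the scatter.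

Compound 4 `O[C@H](COc1ccc(F)cc1)CN1CCN(c2ccc(F)cc2)CC1`, not yet measured, arises from compound 3 by the same change, (fluoro in place of chloro on an aromatic carbon). A step of similar small size is expected for compound 4, because a number 3.3 percentage points higher from compound 2 to compound 1 (within the scatter) lay within the scatter. The expected step is a number 2.7 percentage points higher from compound 3 to compound 4 (within the scatter). Compound 4 is thus estimated at 31% in this assay, with a range from 18% to 44%.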

Compound 4, a percentage reported as inhibition, at one concentration (the size of the read-out at that concentration, not a potency): 50%
Compound 4: middle estimate off by 19 percentage points, on the low side, and the stated range ends below it.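

In this assay the change gives a number 21.7 percentage points higher from compound 3 to compound 4 (beyond the scatter), so the small step on the core of compound 1 did not carry over in size to the core of compound 3. The size of this step therefore depends on the core within this pair of cores: the same change on two cores in this assay, a number 3.3 percentage points higher (within the scatter) from compound 2 to compound 1 and a number 21.7 percentage points higher (beyond the scatter) from compound 3 to compound 4, 18.4 percentage points apart, beyond the scatter of two such steps

This rests on one pair of compounds per core; it does not show why the two steps differ or how the change would behave on any further core.

Open, from the compounds shown here alone, is where a bromo or methyl group would fall at the same place, para to a large group, on either core. Also open, going by these compounds, is whether an amine or a carboxylic acid there would depend on the core in the same way.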